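This account rests on a few compounds, and the source may have more. Where it says the series, first, only, none or still open, it means among the compounds named here.

Measured so far in a functional assay on HEK293 cells for agonist activity at Bombesin receptor subtype-3 (Mus musculus), read by luminescence and calcium flux, with a stated time of 10 min; on this read-out higher numbers stand for an effect only at larger amounts of compound and lower numbers for an effect already at smaller amounts:
- compound 1 `CCC(C)(C)Cc1c[nH]c(CCc2ccc(-n3ncnn3)cc2)n1`: 25 nM
- compound 2 `CCC(C)(C)Cc1c[nH]c(CCc2ccc(-c3cnccn3)cc2)n1`: 11 nM
- compound 3 `c1ccc(-c2ccc(CCc3nc(CC4CCCC4)c[nH]3)cc2)nc1`: 22 nM

Compound 2 sits at the low end of the set. Among the compounds with values here, its gap to compound 3 is within the scatter, so the two cannot be ordered; compound 1 lies further off, and the only step between compounds that differ in one place is a 2.3-fold lower number from compound 1 to compound 2 (0.36 log units; beyond the scatter), a modest change that does stand beyond the scatter.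

Compound 4 `CCC(C)(C)Cc1c[nH]c(CCc2ccc(-c3cnsc3)cc2)n1` is not yet measured. Against compound 2 it differs in one place: 1,2-thiazol-4-yl in place of pyrazin-2-yl on an aromatic carbon. Within the data shown here, no measured pair bears directly on this exchange. Among the measured compounds shown here, the one step available, from compound 1 to compound 2, swaps one aromatic heterocycle for another at the same place and moved the number modestly; compound 4 again swaps the heterocycle at that place, this time to a five-membered ring, and the step is the only guide to what a change of this kind can do here.

The expectation for compound 4 is therefore a step of about a 1.6-fold higher number from compound 2 to compound 4 (0.21 log units; within the scatter), most likely small and, if anything, toward a slightly higher number, not clearly beyond the scatter. The estimate for compound 4 in this assay is 18 nM, with a range from 7 nM to 45 nM.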

Compound 4, half-maximal effective concentration: 6.9 nM
Beside the measured number, compound 4's estimate is 2.6-fold (0.42 log units) above it; measured number below the stated range.
By their numbers in this assay, from the lowest: compounds 4, 2, 3 and 1 (each within the scatter of the next, the first and the last beyond it).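

In this assay, the five-membered 1,2-thiazol-4-yl, on an aromatic carbon para to a large group, does as well as the six-membered pyrazin-2-yl: a 1.6-fold lower number from compound 2 to compound 4 (0.20 log units; within the scatter) does not separate the two rings, so ring size and the sulfur they do not share make no readable difference in this pair. Against 2H-tetrazol-2-yl the same exchange can be read, with a 3.6-fold lower number from compound 1 to compound 4 (0.56 log units; beyond the scatter) set alongside a 2.3-fold lower number from compound 1 to compound 2 (0.36 log units; beyond the scatter) and both standing clear of the scatter, so that in these three compounds the tetrazole compound is the one that separates from the other two. Nothing at hand gives a reason for these differences between the rings.

From the compounds shown here alone, all three groups at this place are aromatic heterocycles, so what a morpholine, a simple amine or a carboxylic acid would do on the same carbon stays open. Also open is whether the order among these rings would hold with the other side chain carried by compound 3, since no pair shown changes that chain alone.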